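Working notes: tert-butoxycarbonyl removal in two cores

The source may report more compounds than this note shows. Statements on the series, on what has been measured and on what is new or still open speak of the compounds shown alone.

Measured in an ADME assay on cells (Splenocyte, Mus musculus, strain BALB/c) for cytotoxicity, read by CCK-8 assay, with a stated time of 48 h; a lower number here means that less compound is tolerated, a higher number that more compound is tolerated:
compound 1, `COc1cc(-c2noc(-c3ccc(NC(=O)OC(C)(C)C)cc3)n2)cc(OC)c1OC`: 9200 nM
compound 2, `COc1cc(-c2noc(-c3ccc(N)cc3)n2)cc(OC)c1OC`: > 50000 nM, a limit of the assay, not a number.
compound 3, `COc1cc(-c2noc(C34CCC(NC(=O)OC(C)(C)C)(CC3)CC4)n2)cc(OC)c1OC`: 12700 nM

Compound 1 and compound 2 differ by hydrogen in place of tert-butoxycarbonyl on a nitrogen on an aromatic ring. In this assay that change gave an at least 5.4-fold higher number from compound 1 to compound 2 (0.73 log units; beyond the scatter), and the second value is the limit of > 50000 nM in this assay, at which 1 of the 3 values shown sits, so the true size of the step is open-ended.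

Compound 3 carries the same protecting group on a different core; how the core of compound 3 differs from that of compound 1 is not broken down here. The values of compound 3 and compound 1 in this assay sit within the scatter of each other.

Compound 4, `COc1cc(-c2noc(C34CCC(N)(CC3)CC4)n2)cc(OC)c1OC`, is not yet measured. It differs from compound 3 by hydrogen in place of tert-butoxycarbonyl on an amine nitrogen. The change is the same kind of change as from compound 1 to compound 2, but the place differs: there the nitrogen sits on an aromatic ring with aromatic carbon as its other neighbour, here it is an amine nitrogen with saturated ring carbon as its other neighbour.

Resting on an at least 5.4-fold higher number from compound 1 to compound 2 (0.73 log units; beyond the scatter), the step from compound 3 to compound 4 in this assay is expected to be a 4.7-fold higher number from compound 3 to compound 4 (0.67 log units; beyond the scatter), most likely ending at the assay limit. Compound 4 is therefore estimated at 60000 nM, between 25000 nM and 150000 nM.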

Compound 4, half-maximal cytotoxic concentration: 25800 nM
The estimate for compound 4 lay 2.3-fold (0.37 log units) above the measured number; measured number inside the range.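

In this assay the change on the second core gave a 2.0-fold higher number from compound 3 to compound 4 (0.31 log units; beyond the scatter), so the free amine carries the higher number on both cores shown: the same change on two cores in this assay, an at least 5.4-fold higher number (0.73 log units; beyond the scatter) from compound 1 to compound 2 and a 2.0-fold higher number (0.31 log units; beyond the scatter) from compound 3 to compound 4; the limit leaves it open whether they differ

Compound 2 gives > 50000 nM, which is a limit of the assay.

The direction of the change therefore carries over from the core of compound 1 to the core of compound 3, but these two pairs do not show that its size carries over, and they cannot say whether the step is smaller on one core than on the other.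

The compounds shown leave open whether an acetyl or a methyl group on the same nitrogen would fall with the tert-butoxycarbonyl compounds or with the free amines. They also leave open whether the same direction would hold on a third core, as two pairs give no general rule for the series.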